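The source may hold more compounds than are shown below. What is called first, only, known or untested is meant among the compounds shown, and "the series" means these compounds.

Measured so far in an assay on isolated protein for agonist activity at Free fatty acid receptor 1 (Homo sapiens); a higher number here means that more compound is needed for the effect, a lower number that less compound is needed:
Compound 1 `CC#CC(CC(=O)O)c1ccc(OCc2ccc3nc(-c4ccc(CC)cc4)cn3c2)cc1` gives 496 nM.
Compound 2 `CC#CC(CC(=O)O)c1ccc(OCc2ccc3nc(-c4ccc(C(F)(F)F)cc4)cn3c2)cc1` gives 558 nM.
Compound 3 `CC#CC(CC(=O)O)c1ccc(OCc2ccn3cc(-c4ccc(C(F)(F)F)cc4)nc3c2)cc1` gives 674 nM.

Compound 1 has the lowest of the three numbers, but both compound 2 and compound 3 lie within the scatter of it, so no order among the three can be read. Compound 4 `CC#CC(CC(=O)O)c1ccc(OCc2ccc3nc(-c4cccc(C)c4)cn3c2)cc1` differs from compound 1 by 3-methylphenyl in place of 4-ethylphenyl on an aromatic carbon. Within the data shown here, the only measured step at that place is a 1.1-fold higher number from compound 1 to compound 2 (0.05 log units; within the scatter), which swapped the group on the same phenyl ring and stayed within the scatter. Among the measured compounds shown here, no measured pair exchanges a 4-ethylphenyl for a 3-methylphenyl, so the expectation rests on that single step and on the narrow spread of the series. In this assay a step of about a 1.1-fold higher number from compound 1 to compound 4 (0.04 log units; within the scatter) is expected, that is none beyond the scatter. Compound 4 is therefore estimated at 550 nM, with a range of 250 nM to 1200 nM.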

Compound 4, half-maximal effective concentration: 1050 nM
For compound 4 the middle estimate is 1.9-fold (0.28 log units) below the measured one; the measured number falls inside the stated range.
By their numbers in this assay, from the lowest: compounds 1, 2, 3 and 4 (each within the scatter of the next, the first and the last beyond it).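

Among these compounds, the exchange of 4-ethylphenyl for 3-methylphenyl is the first step to pass the scatter (a 2.1-fold higher number from compound 1 to compound 4 (0.33 log units; beyond the scatter)), so this position does not tolerate every change of phenyl substituent equally. Against the 4-(trifluoromethyl)phenyl of compound 2, the same group stays within the scatter (a 1.9-fold higher number from compound 2 to compound 4 (0.27 log units; within the scatter)). No measurement available here explains the step from compound 1.

The substituent's ring position and its chain length change together in compound 4, and the compounds shown cannot separate the two. As far as these compounds go, a 4-methylphenyl or a phenyl ring carrying an amine at this position remains open.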